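The source may hold more compounds than are shown below. What is called first, only, known or untested is meant among the compounds shown, and "the series" means these compounds.

Measured compounds in a functional assay on A375-C5 cells (Homo sapiens) for inhibition, read by sulforhodamine B assay, with a stated time of 48 h; on this read-out higher numbers stand for weaker inhibition of growth and lower numbers for stronger inhibition of growth:

- compound 1 `COC(=O)c1sc2cc(C#Cc3cccnc3)cnc2c1N`, for which compound 1 gives > 150000 nM, a limit of the assay rather than a number
- compound 2 `COC(=O)c1sc2cc(C#Cc3ccc(N(C)C)cc3)cnc2c1N`, for which compound 2 gives 17700 nM
- compound 3 `COC(=O)c1sc2cc(C#Cc3ccsc3)cnc2c1N`, for which compound 3 gives 29600 nM

Compound 3 thus holds the higher of the two numbers that are numbers, yet compound 2 sits within the scatter of it, so the two cannot be ranked. Compound 4 `COC(=O)c1sc2cc(C#Cc3ccccc3)cnc2c1N` differs from compound 3 in one place: phenyl in place of thiophen-3-yl on a triple-bonded carbon. Within the data shown here, the only measured step touching this position is an at least 5.0-fold lower number from compound 1 to compound 3 (0.70 log units; beyond the scatter), which shows that the ring on the triple-bonded carbon can move the number well beyond the scatter. Compound 2, which also carries a six-membered carbon ring at that position, gives a value within the scatter of compound 3. On that basis the step is expected to be small, a 1.3-fold lower number from compound 3 to compound 4 (0.13 log units; within the scatter), and compound 4 is estimated at 22000 nM in this assay, between 7000 nM and 70000 nM.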

Compound 4, concentration for 50% growth inhibition: > 150000 nM
Compound 4 ended at the assay's limit; the forecaster's own chance of this, stated with the estimate: 8%; at least 6.8-fold (0.83 log units) between middle value and limit.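

In this assay, the exchange of thiophen-3-yl for phenyl on the triple-bonded carbon gives an at least 5.0-fold higher number from compound 3 to compound 4 (0.70 log units; beyond the scatter), so two aromatic rings that differ only modestly in size are not interchangeable at this position. Hydrogen in place of dimethylamino on an aromatic carbon gives an at least 8.4-fold higher number from compound 2 to compound 4 (0.92 log units; beyond the scatter), which shows that the six-membered carbon ring alone does not account for the value of compound 2 and that the dimethylamino group matters on this ring. The step between the pyridin-3-yl and phenyl compounds cannot be read, since both values are limits: the limit of > 150000 nM in this assay, at which 2 of the 4 values shown sit.

The compounds shown leave open whether a methoxy group or a primary amine on the phenyl ring would also bring the number down. They also leave open whether a furan ring on the triple-bonded carbon would match thiophen-3-yl.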